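From methoxy to isopropoxy on compound 3

A few compounds are considered here, and "the series" means these few. Any claim that something is new, unique, unknown or untested is made for them only; others in the source may bear on it.

Measured so far in a physicochemical assay for lipophilicity, at pH 7.4; on this read-out higher numbers stand for higher lipophilicity and lower numbers for lower lipophilicity
- compound 1 `COc1cccc(C(=O)NCc2c(C)cc(C)[nH]c2=O)c1F` gives 1.4
- compound 2 `Cc1cc(C)c(CN2CCc3c(Cl)cc(-c4cn[nH]c4)c(Cl)c3C2=O)c(=O)[nH]1` gives 3
- compound 3 `COc1cccc(C(=O)NCc2c(C)cc(C)[nH]c2=O)c1Cl` gives 1.2

The starting point is compound 3 with its value of 1.2 on this scale. It cannot be told apart from compound 1 here, as the two lie within the scatter of each other. Compound 2 stands clearly apart from both, at 3 in this assay (a number well clear of the scatter).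

Compound 4 `Cc1cc(C)c(CNC(=O)c2cccc(OC(C)C)c2Cl)c(=O)[nH]1` is still unmeasured. It differs from compound 3 in one place isopropyl in place of methyl on an oxygen on an aromatic ring, which reads as methoxy to isopropoxy.

Among the measured compounds shown here, only one measured step links two compounds by a single change, a number 0.20 log units lower from compound 1 to compound 3 (within the scatter) (a small one). It is chloro in place of fluoro on an aromatic carbon, a different change at a different place, so it gives no direct guide to this one. The expectation therefore rests on the structural change alone, and the range is kept wide. The entering group contains only carbon and is the larger of the two, so an upward move beyond the scatter is expected, namely a number 0.70 log units higher from compound 3 to compound 4 (beyond the scatter) (an estimate). Compound 4 is estimated at 1.9 in this assay with an expected range from 1.5 to 2.4 (both estimates).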

Compound 4, distribution coefficient: 2
Compound 4: the middle estimate sits 0.10 log units below what was measured, within the range that was stated.
By their numbers in this assay, from the lowest: compounds 3 and 1 (each within the scatter of the next); then compound 4; then compound 2.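

Among the compounds shown here, compound 4 gives the first look at a change on the oxygen on the aromatic ring, and in this assay putting isopropyl in place of methyl there gives a number 0.80 log units higher from compound 3 to compound 4 (beyond the scatter). The only earlier single-place step, a number 0.20 log units lower from compound 1 to compound 3 (within the scatter), put chloro in place of fluoro on an aromatic carbon, so this is the first single change among the compounds shown that moves the number by more than repeat measurements would. Nothing at hand gives a reason for this move, so it stands as an observation on this one pair.

Going by these compounds, whether the number would keep climbing with a longer chain on the same oxygen, such as butyl, or would drop with a chain carrying an amine, remains open. The compounds shown also leave open whether methoxy to isopropoxy would give a step of similar size on compound 1, which carries fluoro rather than chloro, and whether a cyclopropyl group on that oxygen would behave like isopropyl.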